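A few compounds are considered here, and "the series" means these few. Any claim that something is new, unique, unknown or untested is made for them only; others in the source may bear on it.

In a physicochemical assay for lipophilicity, read by HPLC, at pH 7.4 (a lower number here means a more polar compound, a higher number a more lipophilic compound), compound 2 `CCOC(=O)C1=C(C)N/C(=C/c2cc(C)n(-c3ccc(OC)cc3)c2C)C1=O` gives 3. Going by the values given here, compound 1 `CCOC(=O)C1=C(O)/C(=C\c2cc(C)n(-c3ccc(F)cc3)c2C)N=C1C` gives 2.9 in this assay, a number that sits within the usual scatter of the one for compound 2, while compound 3 `CCOC(=O)C1=C(C)N/C(=C/c2cc(C)n(-c3cc(OC)c(OC)c(OO)c3)c2C)C1=O` gives 2.6, which lies beyond the scatter and lower than compound 2. Compound 4 `CCOC(=O)C1=C(C)N/C(=C/c2cc(C)n(-c3cccnc3)c2C)C1=O` has not yet been measured in this assay. It differs from compound 2 in one place: pyridin-3-yl in place of 4-methoxyphenyl on an aromatic nitrogen. Among the compounds with values here, no measured pair shows this same change, so its size cannot be read off directly. A shift toward the more polar end, clearly beyond the scatter, is expected for compound 4 in this assay. The expected step is a number 1.20 log units lower from compound 2 to compound 4 (beyond the scatter). Compound 4 is therefore estimated at 1.8, within a range from 1.3 to 2.3.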

Compound 4, distribution coefficient: 2.1
Beside the measured number, compound 4's estimate is 0.30 log units below it; the measured number falls inside the stated range.
By their numbers in this assay, from the lowest: compound 4; then compounds 3, 1 and 2 (each within the scatter of the next, the first and the last beyond it).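

In this assay, the group on the aromatic nitrogen can clearly move the number: pyridin-3-yl in place of 4-methoxyphenyl gives a number 0.90 log units lower from compound 2 to compound 4 (beyond the scatter). Going by these compounds alone, this is the first step here that changes a single place, which the earlier compounds, differing in more than one place, could not offer. Nothing available explains why the number moves.

Open, as far as these compounds go, is how much of the step comes from losing the methoxy group and how much from the ring nitrogen; a plain phenyl group here would separate the two. From the compounds shown here alone, whether pyridin-4-yl would give a similar number also remains open.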